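Pyridyl ether benzamides: oral exposure and the amide substituent

The source may hold more compounds than are shown below. What is called first, only, known or untested is meant among the compounds shown, and "the series" means these compounds.

Measured compounds in an ADME assay on the whole organism (plasma, Mus musculus) for pharmacokinetics, read by LC-MS, at a dose of 30 mg/kg by the oral route; a higher number here means more compound in the circulation at the dose given, a lower number less compound in the circulation:
Compound 1 `NCc1cc(Oc2cccc(C(=O)NCCS(N)(=O)=O)c2)nc(C(F)(F)F)c1` gives 1040 nM in this assay.
Compound 2 `NCc1cc(Oc2cccc(C(=O)N3CC[C@@H](N)C3)c2)nc(C(F)(F)F)c1` gives 670 nM in this assay.
Compound 3 `NCc1cc(Oc2cccc(C(=O)NCCn3cnnn3)c2)nc(C(F)(F)F)c1` gives 1990 nM in this assay.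

The three compounds share one core and differ only in the group on the carbonyl carbon. Among the measured compounds shown here, compound 3 sits at the top of the numbers so far: the step from compound 1 is a 1.9-fold higher number from compound 1 to compound 3 (0.28 log units; within the scatter), so those two are not separable, while the step from compound 2 is a 3.0-fold higher number from compound 2 to compound 3 (0.47 log units; beyond the scatter). The step of a 1.6-fold lower number from compound 1 to compound 2 (0.19 log units; within the scatter) likewise stays inside the scatter.

Compound 4 `NCc1cc(Oc2cccc(C(=O)N3CC[C@@H](O)C3)c2)nc(C(F)(F)F)c1` has not been measured in this assay. Relative to compound 3 the change is a group of 6 heavy atoms (4 carbon, 1 nitrogen, 1 oxygen; one five-membered non-aromatic ring with 1 hetero atom) in place of a group of 8 heavy atoms (3 carbon, 5 nitrogen; one five-membered aromatic ring with 4 hetero atoms), on a carbonyl carbon.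

The step that bears most directly on this is a 3.0-fold higher number from compound 2 to compound 3 (0.47 log units; beyond the scatter), which runs the other way: a five-membered non-aromatic ring with one hetero atom on the carbonyl carbon gave a modestly lower number than the tetrazolyl chain. For the measured compounds named here, compound 4 carries a 3-hydroxypyrrolidin-1-yl rather than the 3-aminopyrrolidin-1-yl of compound 2, and no measured pair shows that exchange, so the size of any difference there is unknown. On the evidence available, a modest decrease is expected for compound 4, of the order of a 2.2-fold lower number from compound 3 to compound 4 (0.34 log units; beyond the scatter), with the two rings treated as comparable. The estimate for compound 4 in this assay is 900 nM, in the range 350 nM to 2300 nM.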

Compound 4, maximal plasma concentration: 5130 nM
Beside the measured number, compound 4's estimate is 5.7-fold (0.76 log units) below it; measured number outside the range, above it.
By their numbers in this assay, from the lowest: compounds 2, 1 and 3 (each within the scatter of the next, the first and the last beyond it); then compound 4.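

In this assay the group on the carbonyl carbon now gives a spread well beyond the scatter, and the cleanest reading comes from a single exchange, hydroxy in place of amino on a saturated ring carbon, with a 7.7-fold higher number from compound 2 to compound 4 (0.88 log units; beyond the scatter) as its step. A five-membered non-aromatic ring on the carbonyl carbon therefore does not by itself go with the low end of the series: what the ring carries on its saturated carbon decides much of the outcome in this pair, and 3-hydroxypyrrolidin-1-yl also exceeds both open-chain groups, with a 2.6-fold higher number from compound 3 to compound 4 (0.41 log units; beyond the scatter) as one step and a 4.9-fold higher number from compound 1 to compound 4 (0.69 log units; beyond the scatter) as the other, which leaves compound 4 alone at the top, beyond the scatter from all three others. Nothing at hand accounts for these steps, so they stand as observations only.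

Still open, going by these compounds, is whether hydroxy itself matters or whether any neutral group would serve on that saturated ring carbon, as a methoxy group or a fluorine atom there would show. Also open, on these data alone, is how far the result depends on the defined stereocentre and on the five-membered ring, which the opposite enantiomer and a 4-hydroxypiperidin-1-yl group on the carbonyl carbon would test.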